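Three hydroxyazole amides measured, a fourth one awaited

A few compounds are considered here, and "the series" means these few. Any claim that something is new, unique, unknown or untested is made for them only; others in the source may bear on it.

Compound 1, `O=C(Nc1cc(C(F)(F)F)cc(C(F)(F)F)c1)c1nsnc1O`, in an assay on isolated protein for inhibition of mitogen-activated protein kinase kinase kinase 14 (Homo sapiens), read by ADP-Glo, with a stated time of 60 min, in the presence of a further agent that is not named here (a lower number here means a stronger inhibitor, a higher number a weaker inhibitor), gives > 100000 nM, which is a limit of the assay and not a number.
Compound 2, `Cn1nc(O)c(C(=O)Nc2cc(C(F)(F)F)cc(C(F)(F)F)c2)n1`, in this assay gives > 100000 nM, again a limit of the assay.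
Compound 3, `O=C(Nc1cc(C(F)(F)F)cc(C(F)(F)F)c1)c1n[nH]nc1O`, in this assay gives > 100000 nM, also a limit of the assay.

All three measured values sit at the same limit, as the limit of > 100000 nM in this assay, at which 3 of the 3 values shown sit, records. Compound 3 therefore stands nowhere in particular on the numbers shown: it is known only as a limit, and so are the two compounds beside it. The steps a step that the two limits leave unreadable from compound 1 to compound 2, a step that the two limits leave unreadable from compound 1 to compound 3 and a step that the two limits leave unreadable from compound 2 to compound 3 are all unreadable. Each of them joins two limits.

Compound 4, `Cn1cc(C(=O)Nc2cc(C(F)(F)F)cc(C(F)(F)F)c2)c(O)n1`, has not yet been measured. It differs from compound 3 by 3-hydroxy-1-methyl-1H-pyrazol-4-yl in place of 5-hydroxy-2H-1,2,3-triazol-4-yl on a carbonyl carbon. Every measured step that might inform this change is unreadable, so no direction can be taken from them; what the data do show is that three variations of the ring on the carbonyl carbon all stayed at the limit.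

On that basis, compound 4 is expected to stay at the limit as well, with the step of a number no higher from compound 3 to compound 4 (the limit leaves the size open) estimated as no change beyond the scatter. The estimate for compound 4 in this assay is 100000 nM, within a range from 20000 nM to 500000 nM.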

Compound 4, half-maximal inhibitory concentration: > 100000 nM
Compound 4 gave a limit, no number; the forecaster's own chance of this, stated with the estimate: 85%; the middle value sits exactly at the limit.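

Compound 4 stays at a limit of the assay, as do compound 1, compound 2 and compound 3, so none of the steps from compound 3, compound 2 or compound 1 to compound 4 can be read: the limit of > 100000 nM in this assay, at which 4 of the 4 values shown sit.

The compounds shown leave open what number any of them would give in this assay and whether changing the ring on the carbonyl carbon alters inhibition at all.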